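The compounds below may be only part of what the source reports. "The series", "measured", "known", "first", "only" and "open" are said of these compounds alone.

Compound 1 `O=C(O)CC/C=C\CO[C@H]1C(OCc2ccc(-c3ccccc3)cc2)CC[C@@H]1N1CCCCCC1` stands second highest of the three numbers in a functional assay on blood for antagonist activity at thromboxane A2 receptor (Homo sapiens) (a lower number here means tighter binding, a higher number weaker binding), where compound 1 gives 12.6 nM. Compound 3 `O=C(O)CC/C=C\CO[C@H]1C(OCc2ccc(-c3ccccc3CCO)cc2)CC[C@@H]1N1CCCCCC1` gives 2 nM in this assay, and compound 2 `O=C(O)CC/C=C\CO[C@@H]1[C@@H](OCc2ccc(-c3ccccc3)cc2)CC[C@@H]1N1CCCCC1` gives 100 nM. Compound 4 `O=C(O)CC/C=C\CO[C@H]1C(OCc2ccc(-c3ccccc3O)cc2)CC[C@@H]1N1CCCCCC1` differs from compound 1 by hydroxy in place of hydrogen on an aromatic carbon. Going by the values given here, the one step that bears on this change is a 6.3-fold lower number from compound 1 to compound 3 (0.80 log units; beyond the scatter), where 2-hydroxyethyl entered on an aromatic carbon; a hydroxy at that carbon is a related change, so a step in the same direction, beyond the scatter but resting on a single pair, is expected, and the estimated step is a 2.5-fold lower number from compound 1 to compound 4 (0.40 log units; beyond the scatter). Compound 4 is therefore expected at 5 nM, with a range from 1.6 nM to 16 nM.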

Compound 4, dissociation constant: 15.9 nM
For compound 4 the middle estimate is 3.2-fold (0.50 log units) below the measured one, within the range that was stated.
By their numbers in this assay, from the lowest: compound 3; then compounds 1 and 4 (each within the scatter of the next); then compound 2.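

In this assay, hydroxy on this aromatic carbon gives a 1.3-fold higher number from compound 1 to compound 4 (0.10 log units; within the scatter), within the scatter, so the drop seen with 2-hydroxyethyl does not extend to this shorter group. The step of an 8.0-fold higher number from compound 3 to compound 4 (0.90 log units; beyond the scatter) shows that the two groups are not interchangeable at this position, and that a hydroxy directly on the aromatic carbon is not enough to reproduce the number of compound 3. No measurement on hand accounts for this difference. Still open, as far as these compounds go, is whether a 3-hydroxypropyl chain, a carboxylic acid or an amine at this carbon would read like compound 3 or like compound 4.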